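Pyrazole in Place of Oxane: Expecting Compound 4

A few compounds are considered here, and "the series" means these few. Any claim that something is new, unique, unknown or untested is made for them only; others in the source may bear on it.

Measured in an ADME assay on Caco-2 cells (Homo sapiens) for permeability, in the apical to basolateral direction; on this read-out higher numbers stand for higher permeability and lower numbers for lower permeability:
Compound 1 `COCc1ccc(-c2ccc3nnc(C(N)=O)c(N[C@@H](C)C4CCOCC4)c3c2)cn1` gives 0.7 10^-6 cm/s
Compound 2 `COCc1ccc(-c2ccc3nnc(C(N)=O)c(N[C@@H](C)c4nn(C)cc4C)c3c2)cn1` gives 0.9 10^-6 cm/s
Compound 3 `CNC(=O)c1nnc2ccc(-c3ccc(OCCCN(C)C)nc3)cc2c1N[C@@H](C)C1CCOCC1` gives 2.6 10^-6 cm/s

Compound 2 differs from compound 1 in one place: 1,4-dimethyl-1H-pyrazol-3-yl in place of oxan-4-yl on a saturated chain carbon bound to a nitrogen on an aromatic ring and a saturated chain carbon. This change made a step of a 1.3-fold higher number from compound 1 to compound 2 (0.11 log units; within the scatter), so the two values cannot be told apart. Compound 3 carries a different core, and the difference between the two cores is not broken down here. Compound 3 holds the highest of the three numbers, beyond the scatter against both compound 1 and compound 2.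

Compound 4 `CNC(=O)c1nnc2ccc(-c3ccc(OCCCN(C)C)nc3)cc2c1N[C@@H](C)c1nn(C)cc1C` is not yet measured. It relates to compound 3 exactly as compound 2 relates to compound 1, the same change in the same place: 1,4-dimethyl-1H-pyrazol-3-yl in place of oxan-4-yl on a saturated chain carbon bound to a nitrogen on an aromatic ring and a saturated chain carbon. Going by the values given here, since the only comparable step is a 1.3-fold higher number from compound 1 to compound 2 (0.11 log units; within the scatter), a step of about the same size is expected here, namely a 1.3-fold higher number from compound 3 to compound 4 (0.10 log units; within the scatter) in this assay. On that basis compound 4 is estimated at 3.3 10^-6 cm/s, with a likely range from 1.6 10^-6 cm/s to 6.5 10^-6 cm/s, because the change on the core of compound 1 stayed within the scatter in a 1.3-fold higher number from compound 1 to compound 2 (0.11 log units; within the scatter).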

Compound 4, apparent permeability: 1.6 10^-6 cm/s
Beside the measured number, compound 4's estimate is 2.1-fold (0.31 log units) above it, and the stated range covers the measured number.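

In this assay, putting 1,4-dimethyl-1H-pyrazol-3-yl in place of oxan-4-yl gives a 1.6-fold lower number from compound 3 to compound 4 (0.21 log units; within the scatter), so on this core too the two groups cannot be told apart. Set side by side, the two steps on the two cores agree as far as these measurements can tell: the same change on two cores in this assay, a 1.3-fold higher number (0.11 log units; within the scatter) from compound 1 to compound 2 and a 1.6-fold lower number (0.21 log units; within the scatter) from compound 3 to compound 4, 2.1-fold (0.32 log units) apart, within the scatter of two such steps. Going by these compounds alone, this shows that the change carried from the core of compound 1 to the core of compound 3 without a step beyond the scatter, but it rests on only two pairs of compounds and does not show that the same would hold on any other core.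

The compounds shown leave open how a phenyl or cyclohexyl group would read on the same saturated chain carbon, since only these two groups appear there. They also leave open whether the change would stay this small on a third core, for example one with a carboxylic acid in place of the amide.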